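A few compounds are considered here, and "the series" means these few. Any claim that something is new, unique, unknown or untested is made for them only; others in the source may bear on it.

Measured so far, in a functional assay on the whole organism (strain albino) for inhibition, with Rattus norvegicus as the target, read by paw edema, with stated times of 30 min and 5 h, at a dose of 0.28 mmol/kg by the oral route; a lower number here means less inhibition, a higher number more inhibition at the dose given (going by the name of the read-out):
compound 1, `C=CCn1c(SCC(=O)Nc2ccc(/C(C)=N/O)cc2)nnc1-c1ccccc1`: 71%
compound 2, `CCn1c(SCC(=O)Nc2ccc(/C(C)=N/O)cc2)nnc1-c1ccc(OC)cc1`: 65%
compound 3, `C=CCn1c(SCC(=O)Nc2ccc(/C(C)=N/O)cc2)nnc1-c1ccc(OC)c(OC)c1`: 79%

Compound 3 has the highest number of the three, though its gap to compound 1 lies within the scatter; only compound 2 sits clearly lower. The shared core carries a phenyl ring whose substituents vary. Compound 4, `C=CCn1c(SCC(=O)Nc2ccc(/C(C)=N/O)cc2)nnc1-c1ccc(OC)cc1`, is compound 3 with hydrogen in place of methoxy on an aromatic carbon. Among the compounds with values here, the one step that bears on this, a number 8 percentage points higher from compound 1 to compound 3 (within the scatter), was small, so adding or removing methoxy groups on this ring has so far changed little. Compound 2 also carries 4-methoxyphenyl, but differs in a second place as well, so its value only hints. Compound 4 is therefore expected to sit near compound 3, with a number 7 percentage points lower from compound 3 to compound 4 (within the scatter), estimated at 72% within 60% to 82%.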

Compound 4, a percentage reported as inhibition, in the whole organism at one dose (the size of the read-out at that dose, not a potency): 72%
Beside the measured number, compound 4's estimate shows no gap at the digits printed; measured number inside the range.
By their numbers in this assay, from the lowest: compounds 2, 1, 4 and 3 (each within the scatter of the next, the first and the last beyond it).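

In this assay, hydrogen in place of methoxy gives a number 7 percentage points lower from compound 3 to compound 4 (within the scatter) and methoxy in place of hydrogen gives a number 1 percentage points higher from compound 1 to compound 4 (within the scatter) on the same ring, so none, one or two methoxy groups cannot be told apart here. Vinyl in place of methyl on the chain bound to an aromatic nitrogen gives a number 7 percentage points higher from compound 2 to compound 4 (within the scatter) and so has no clear effect either. No supporting data explain these small steps.

On these data alone, whether an amine or a carboxylic acid on this ring, or a longer chain on that nitrogen, would move the number beyond the scatter stays open.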